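This account rests on a few compounds, and the source may have more. Where it says the series, first, only, none or still open, it means among the compounds named here.

Measured compounds in a functional assay on the whole organism (strain CF-1) with Mus musculus as the target, in the writhing test, with a stated time of 15 min; on this read-out lower numbers stand for an effect already at smaller amounts and higher numbers for an effect only at larger amounts of compound:
compound 1 `O=C(/N=C1\NC2(CCCCO2)CCS1)Nc1ccccc1`, a limit of this assay, > 200 mg/kg.
compound 2 `O=C(/N=C1\NC2(CCCCO2)CCS1)c1ccc(F)cc1`, several entries, 8.8 mg/kg; 28 mg/kg; 49 mg/kg (3 entries).
compound 3 `Cc1ccc(C(=O)/N=C2\NC3(CCCCO3)CCS2)cc1`, 60 mg/kg.

Among the measured compounds shown here, compound 3 holds the only single number in this assay; compound 1 sits at a limit and compound 2 has several entries rather than one number. For the measured compounds named here, the one step measured within the set, an at least 3.3-fold lower number from compound 1 to compound 3 (0.52 log units; beyond the scatter), concerns the substituent on the carbonyl carbon. Compound 4 `CC1(C(=O)/N=C2\NC3(CCCCO3)CCS2)CCCCC1` differs from compound 3 by 1-methylcyclohexyl in place of 4-methylphenyl on a carbonyl carbon. Going by the values given here, no measured step exchanges an aromatic ring for a non-aromatic one, so the precedent is indirect; the spread of compound 2's entries the several entries of compound 2 in this assay, 8.8 mg/kg; 28 mg/kg; 49 mg/kg (3 entries) shows how widely repeats of this assay fall. The expected step is a 1.2-fold higher number from compound 3 to compound 4 (0.07 log units; within the scatter), within the scatter. Compound 4 is therefore estimated at 70 mg/kg, between 25 mg/kg and 200 mg/kg.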

Compound 4, dose for half-maximal effect: > 200 mg/kg
Compound 4: a limit, no number; the forecaster's own chance of this, stated with the estimate: 25%; at least 2.8-fold (0.45 log units) between middle value and limit.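

In this assay, the carbonyl carbon does not tolerate every ring of the same size: with 7 heavy atoms and one six-membered ring on both sides, 1-methylcyclohexyl in place of 4-methylphenyl gives an at least 3.3-fold higher number from compound 3 to compound 4 (0.52 log units; beyond the scatter). Compound 4, at > 200 mg/kg, sits at a limit of the assay. The step between compound 1 and compound 4 cannot be read, since both values are limits.

The compounds shown leave open how a plain cyclohexyl or a pyridyl on the carbonyl carbon would fall. Whether the change follows the loss of the aromatic ring or the 1-methyl group therefore remains unresolved.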